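This account rests on a few compounds, and the source may have more. Where it says the series, first, only, none or still open, it means among the compounds named here.

Series notes. All three measured compounds share one core and differ only in the chain on the amide. Compound 1 `CC/C=C/C(=O)Nc1cc2c(N3CCCc4ccccc43)ncnc2cc1OC` gives 2870 nM in a functional assay on MCF7 cells (Homo sapiens) for antiproliferative activity, read by MTT assay, with a stated time of 72 h; on this read-out higher numbers stand for weaker inhibition and lower numbers for stronger inhibition. Compound 2 `COc1cc2ncnc(N3CCCc4ccccc43)c2cc1NC(=O)/C=C/C(C)C` gives 4290 nM in this assay; the step is a 1.5-fold higher number from compound 1 to compound 2 (0.17 log units; within the scatter). Compound 3 `COc1cc2ncnc(N3CCCc4ccccc43)c2cc1NC(=O)/C=C/CN(C)C` gives 1770 nM in this assay and holds the lowest of the three numbers, with compound 1 nearest and compound 2 furthest; the steps of a 1.6-fold lower number from compound 1 to compound 3 (0.21 log units; within the scatter) and a 2.4-fold lower number from compound 2 to compound 3 (0.38 log units; beyond the scatter) set that position.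

Compound 4 `COc1cc2ncnc(N3CCCc4ccccc43)c2cc1NC(=O)/C=C/CN1CCCCC1` differs from compound 3 by piperidin-1-yl in place of dimethylamino on a saturated chain carbon bound to a double-bonded chain carbon. Among the measured compounds shown here, no measured step enlarges the group at this place. The step that touches the same saturated chain carbon is a 1.6-fold lower number from compound 1 to compound 3 (0.21 log units; within the scatter), where the dimethylamino entered in place of methyl; a 2.4-fold lower number from compound 2 to compound 3 (0.38 log units; beyond the scatter) also ends at compound 3. For the measured compounds named here, both steps are small, and exchanging dimethylamino for piperidin-1-yl is a further change at the same place with no measured precedent in this set. For compound 4 no step beyond the scatter is expected in this assay, and the expected step is a 1.0-fold higher number from compound 3 to compound 4 (0.01 log units; within the scatter). Compound 4 is therefore estimated at 1800 nM, with a range from 800 nM to 4000 nM.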

Compound 4, half-maximal inhibitory concentration: 3930 nM
The estimate for compound 4 lay 2.2-fold (0.34 log units) below the measured number, within the range that was stated.
By their numbers in this assay, from the lowest: compounds 3, 1, 4 and 2 (each within the scatter of the next, the first and the last beyond it).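

Working notes on the position. In this assay, among the compounds shown here, piperidin-1-yl in place of dimethylamino on the saturated chain carbon bound to a double-bonded chain carbon is the first measured change within the amine itself, and it gives a modest step beyond the scatter (a 2.2-fold higher number from compound 3 to compound 4 (0.35 log units; beyond the scatter)). Compound 4 does not keep the separation from compound 2 that compound 3 showed, since both of its steps from the amine-free chains lie within the scatter (a 1.1-fold lower number from compound 2 to compound 4 (0.04 log units; within the scatter); a 1.4-fold higher number from compound 1 to compound 4 (0.14 log units; within the scatter)). Across compounds 3 and 4, then, an amine at this place does not alone go with the lowest number, and the identity of the amine changes the reading, though this rests on a single pair.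

No measurement at hand bears on the reason for the step from dimethylamino to piperidin-1-yl. From the compounds shown here alone, whether pyrrolidin-1-yl, morpholin-4-yl or diethylamino at this place would read with compound 3 or with compound 4 stays open, and with it whether the ring or the larger carbon count goes with the higher number.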